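The compounds below may be only part of what the source reports. "The series", "measured", "known", "first", "only" and "open" are said of these compounds alone.

Working notes on the series.

Compound 1 `CC1=C(C(=O)OC2CCCC2)C(c2csc(-c3ccc(Cl)cc3)n2)C(C(=O)OC2CCCC2)=C(C)N1` carries two cyclopentyl esters on the shared core. For the measured compounds named here, in an assay on isolated protein for antagonist activity at Voltage-dependent L-type calcium channel subunit alpha-1C (Cavia porcellus), with a stated time of 15 min (on this read-out lower numbers stand for stronger inhibition and higher numbers for weaker inhibition), compound 1 gives 19000 nM, the higher of the two numbers measured so far. Compound 2 `CC1=C(C(=O)OCc2ccccc2)C(c2csc(-c3ccc(Cl)cc3)n2)C(C(=O)OCc2ccccc2)=C(C)N1` carries two benzyl esters on the same core, and in this assay compound 2 gives 11000 nM; the two values lie within the scatter of each other, so no order between compound 1 and compound 2 can be read from them.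

Compound 3 `CCOC(=O)C1=C(C)NC(C)=C(C(=O)OC2CCCC2)C1c1csc(-c2ccc(Cl)cc2)n1` is not yet measured. Relative to compound 1 the difference is ethyl in place of cyclopentyl on an oxygen next to a carbonyl group, so that one ester is shortened while the other cyclopentyl ester stays in place. Going by the values given here, no step between measured compounds covers an ester change of this kind, so the size of the effect has no precedent. With the two measured compounds agreeing within the scatter despite differing on both esters, the expectation is a small step from compound 1 to compound 3, estimated as a 1.6-fold lower number from compound 1 to compound 3 (0.20 log units; within the scatter), with no clear direction beyond the scatter. Compound 3 is therefore estimated at 12000 nM, with a range from 4000 nM to 40000 nM.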

Compound 3, half-maximal inhibitory concentration: 8380 nM
Beside the measured number, compound 3's estimate is 1.4-fold (0.16 log units) above it; the measured number falls inside the stated range.
By their numbers in this assay, from the lowest: compounds 3, 2 and 1 (each within the scatter of the next, the first and the last beyond it).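

In this assay, for the compounds shown here, ethyl in place of cyclopentyl on an oxygen next to a carbonyl group gives a 2.3-fold lower number from compound 1 to compound 3 (0.36 log units; beyond the scatter) and is the only step between compounds that differ in one place. The step is modest, but it shows that this ester position has a readable effect on the number, which the two earlier compounds could not show because they differ on both esters. It also shows that the five-membered carbon ring at this position can be lost, with the other cyclopentyl ester in place, without the number rising, though nothing at hand accounts for the direction of the step.

The compounds shown leave open whether the same exchange on the second ester would give a step of similar size and direction, and whether ethyl is the end of the trend or one point along it. A methyl ester, a longer chain such as n-butyl, or an ester chain ending in an amine at this position would show how far the number follows the group on this oxygen.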